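The compounds below may be only part of what the source reports. "The series", "measured", "known", "first", "only" and "open" are said of these compounds alone.

Compound 1 `C/C=C1/[C@H](O[C@@H]2O[C@H](CO)[C@@H](O)[C@H](O)[C@H]2O)OC=C(C(=O)OC)[C@H]1CC(=O)OCCC1CCCCC1` is an ester built on the shared core, with a cyclohexyl group at the end of its ester chain. In a functional assay on HeLa cells (Homo sapiens) for antiproliferative activity, read by MTT assay, with a stated time of 72 h (on this read-out lower numbers stand for stronger inhibition and higher numbers for weaker inhibition), compound 1 gives 5600 nM. Among the measurements shown, this is the only plain number; the one other result is a limit. Compound 2 `C/C=C1/[C@H](O[C@@H]2O[C@H](CO)[C@@H](O)[C@H](O)[C@H]2O)OC=C(C(=O)O)[C@H]1CC(=O)O` shares the core but carries free acids in place of the esters. In this assay compound 2 gives > 50000 nM, and this is a limit of the assay rather than a number, as the limit of > 50000 nM in this assay, at which 1 of the 2 values shown sits, records.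

Compound 3 `C/C=C1/[C@H](O[C@@H]2O[C@H](CO)[C@@H](O)[C@H](O)[C@H]2O)OC=C(C(=O)OC)[C@H]1CC(=O)OCCc1ccc(O)c(O)c1` has not yet been measured. It differs from compound 1 by 3,4-dihydroxyphenyl in place of cyclohexyl on a saturated chain carbon, two bonds along the chain from an oxygen next to a carbonyl group. Within the data shown here, no step between two measured compounds is available to gauge a change of this kind, so any expectation rests on compound 1 alone. Compound 3 is expected to come out weaker than compound 1 by a 3.6-fold higher number from compound 1 to compound 3 (0.55 log units; beyond the scatter), a step beyond the usual scatter but short of the limit. In this assay compound 3 is estimated at 20000 nM, with a likely range from 5000 nM to 80000 nM.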

Compound 3, half-maximal inhibitory concentration: 265000 nM
Beside the measured number, compound 3's estimate is 13-fold (1.12 log units) below it; measured number outside the range, above it.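

Among these compounds, this is the first measured step at this position, on a saturated chain carbon, two bonds along the chain from an oxygen next to a carbonyl group, and it shows that the group at the end of the ester chain matters a great deal. In this assay, with everything else in the molecule unchanged, 3,4-dihydroxyphenyl in place of cyclohexyl gives a 47-fold higher number from compound 1 to compound 3 (1.68 log units; beyond the scatter), so of these two groups cyclohexyl goes with the stronger inhibition of cell growth. This single pair changes the ring and adds the hydroxyl groups at once, and nothing measured here gives a reason for the size of the step.

A plain phenyl group or a 4-hydroxyphenyl group in the same place would help to separate the effect of the aromatic ring from that of the hydroxyl groups. Going by these compounds, it also remains open whether a longer chain, or an amine at the end of the chain, would keep the activity of compound 1, improve on it or lose it.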